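A few compounds are considered here, and "the series" means these few. Any claim that something is new, unique, unknown or untested is made for them only; others in the source may bear on it.

In a functional assay on A549 cells (Homo sapiens) for antiproliferative activity, read by MTT assay, with a stated time of 24 h (on this read-out lower numbers stand for stronger inhibition and higher numbers for weaker inhibition), compound 3 (`Cc1ccc(C)c(S(=O)(=O)n2c(-c3cn(-c4ccccc4)nc3-c3ccc(F)cc3)nc3ccccc32)c1`) gives 200 nM and sits at the low end of the three numbers, together with compound 2 (`COc1ccc(S(=O)(=O)n2c(-c3cn(-c4ccccc4)nc3-c3ccc(F)cc3)nc3ccccc32)cc1`) at 350 nM within the scatter, while compound 1 (`O=S(=O)(c1ccccc1)n1c(-c2cn(-c3ccccc3)nc2-c2ccc(F)cc2)nc2ccccc21`) gives 550 nM here. Compound 4 (`O=[N+]([O-])c1ccc(S(=O)(=O)n2c(-c3cn(-c4ccccc4)nc3-c3ccc(F)cc3)nc3ccccc32)cc1`) puts 4-nitrophenyl in place of 2,5-dimethylphenyl on a sulfonyl sulfur. Within the data shown here, the only guides are earlier changes to the group on that sulfur, all modest at most: a 2.8-fold lower number from compound 1 to compound 3 (0.44 log units; beyond the scatter) and a 1.8-fold lower number from compound 2 to compound 3 (0.24 log units; within the scatter) for whole-group swaps, and a 1.6-fold lower number from compound 1 to compound 2 (0.20 log units; within the scatter) for the methoxy change. Among the measured compounds shown here, no measured compound carries 4-nitrophenyl, so a similarly small step toward a higher number is expected in this assay (a 1.8-fold higher number from compound 3 to compound 4 (0.24 log units; within the scatter)). For compound 4 the estimate is 350 nM with an expected range from 130 nM to 900 nM in this assay.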

Compound 4, half-maximal inhibitory concentration: 1030 nM
Beside the measured number, compound 4's estimate is 2.9-fold (0.47 log units) below it; the whole stated range lies below it.
By their numbers in this assay, from the lowest: compounds 3, 2, 1 and 4 (each within the scatter of the next, the first and the last beyond it).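

In this assay, the group on the sulfonyl sulfur can move the number further than the earlier swaps showed: a 5.2-fold higher number from compound 3 to compound 4 (0.71 log units; beyond the scatter) is the widest step yet, and nitro in place of methoxy also counts, with a 2.9-fold higher number from compound 2 to compound 4 (0.47 log units; beyond the scatter). Nitro in place of hydrogen, however, gives a 1.9-fold higher number from compound 1 to compound 4 (0.27 log units; within the scatter), so compound 4 is not clearly separated from the plain phenyl of compound 1. Nothing measured here explains these steps. As far as these compounds go, it remains open whether an amine or a carboxylic acid on that phenyl ring would fall with nitro or with methoxy, and whether a single methyl would match 2,5-dimethylphenyl.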